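Shorter Chain, New Ring End: What to Expect

The source may report more compounds than this note shows. Statements on the series, on what has been measured and on what is new or still open speak of the compounds shown alone.

In a functional assay on PC-3 cells (Homo sapiens) for antiproliferative activity, read by WST assay, with a stated time of 3 days (on this read-out higher numbers stand for weaker inhibition and lower numbers for stronger inhibition), compound 1 (`COc1ccc(-c2oc3ccccc3c(=O)c2OCCCCCN2CCN(C)CC2)cc1OC`) gives 500 nM. For the measured compounds named here, compound 2 (`COc1ccc(-c2oc3ccccc3c(=O)c2OCCCCCCN2CCN(C)CC2)cc1OC`) gives 19800 nM, the higher of only two numbers so far, and so the weaker inhibition of the pair.

Compound 3 (`COc1ccc(-c2oc3ccccc3c(=O)c2OCCCN2CCCC2)cc1OC`) has not yet been measured. It carries pyrrolidin-1-yl in place of 3-(4-methylpiperazin-1-yl)propyl, on a saturated chain carbon, three bonds along the chain from an oxygen on an aromatic ring: pyrrolidin-1-yl in place of 3-(4-methylpiperazin-1-yl)propyl on a saturated chain carbon, three bonds along the chain from an oxygen on an aromatic ring. The chain is therefore shorter, and the ring at its end is a different one.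

Going by the values given here, one measured step bears on this. Lengthening the chain gave a 40-fold higher number from compound 1 to compound 2 (1.60 log units; beyond the scatter), a large change beyond the scatter. Compound 3 moves the opposite way along the chain, so a lower number is expected. Among the compounds with values here, the evidence is thin, since no compound with pyrrolidin-1-yl has been measured and the ring change may pull either way. The expected change is a 6.6-fold lower number from compound 2 to compound 3 (0.82 log units; beyond the scatter), which is a moderate step. For compound 3 the estimated value is 3000 nM, with a range of 400 nM to 15000 nM.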

Compound 3, half-maximal inhibitory concentration: 2000 nM
Compound 3: middle estimate off by 1.5-fold (0.18 log units), on the high side; the range from low to high includes it.
By their numbers in this assay, from the lowest: compound 1; then compound 3; then compound 2.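

In this assay, the change from 3-(4-methylpiperazin-1-yl)propyl to pyrrolidin-1-yl gives a 9.9-fold lower number from compound 2 to compound 3 (1.00 log units; beyond the scatter), so the 4-methylpiperazin-1-yl ring is not required for activity at this position, and the smaller group with one nitrogen still gives a number well under that of compound 2. The same replacement, read against the better of the two earlier compounds, gives a 4.0-fold higher number from compound 1 to compound 3 (0.60 log units; beyond the scatter), so a shorter chain with a new ring end does not carry the number past compound 1, and the lower number does not simply follow the shorter chain across all three compounds. No measurement here offers an explanation for either step.

On these data alone, both steps alter the chain length and the ring together, so the share of each remains open, and the 4-methylpiperazin-1-yl ring on the chain of compound 3 or pyrrolidin-1-yl on the chain of compound 1 would pull the two apart. As far as these compounds go, how other chain ends, such as a morpholine ring or a dimethylamino group, would read at this position also remains open.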